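Removing the amino group from compound 2

This account rests on a few compounds, and the source may have more. Where it says the series, first, only, none or still open, it means among the compounds named here.

Compound 1 `CC(=O)c1ccc(Oc2ccccc2NC(C)=C2C(=O)CC(c3ccccc3)CC2=O)cc1` - 130 nM
Compound 2 `COc1cc(Oc2ccccc2NC(C)=C2C(=O)CC(c3ccccc3)CC2=O)ccc1N` - 33 nM
Compound 3 `CCOc1ccccc1NC(C)=C1C(=O)CC(c2ccccc2)CC1=O` - 180 nM

In a functional assay on HeLa cells (Homo sapiens) for antiproliferative activity, read by cell counting, with a stated time of 3 days (a higher number here means a weaker inhibitor, a lower number a stronger inhibitor), compound 2 has the lowest number of the three at 33 nM, and its steps to both others lie beyond the scatter. Compound 4 `COc1cccc(Oc2ccccc2NC(C)=C2C(=O)CC(c3ccccc3)CC2=O)c1` differs from it in one place: hydrogen in place of amino on an aromatic carbon. This is hydrogen in place of amino on an aromatic carbon, ortho to a methoxy group and para to a large group, so 4-amino-3-methoxyphenyl becomes 3-methoxyphenyl.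

Among the compounds with values here, no measured step removes the amino group alone. The closest evidence comes from exchanging the whole group: a 3.9-fold lower number from compound 1 to compound 2 (0.60 log units; beyond the scatter) and a 5.5-fold higher number from compound 2 to compound 3 (0.74 log units; beyond the scatter). Neither compound 1 nor compound 3 carries the amino group, and a 1.4-fold higher number from compound 1 to compound 3 (0.14 log units; within the scatter). These steps suggest that a modest rise in the number is likely, though compound 4 keeps the methoxy group and the aromatic ring.

The expected change is a 2.4-fold higher number from compound 2 to compound 4 (0.38 log units; beyond the scatter). For compound 4 the estimated value is 80 nM, with an expected range from 30 nM to 200 nM.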

Compound 4, half-maximal inhibitory concentration: 93 nM
The estimate for compound 4 lay 1.2-fold (0.07 log units) below the measured number; the range from low to high includes it.
By their numbers in this assay, from the lowest: compound 2; then compounds 4, 1 and 3 (each within the scatter of the next).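

In this assay, removing the amino group alone gives a 2.8-fold higher number from compound 2 to compound 4 (0.45 log units; beyond the scatter) and so isolates a change that the earlier whole-group exchanges could not separate from the rest of the substituent. Without the amino group, the comparisons give a 1.9-fold lower number from compound 3 to compound 4 (0.29 log units; within the scatter) and a 1.4-fold lower number from compound 1 to compound 4 (0.15 log units; within the scatter), so 3-methoxyphenyl, ethyl and 4-acetylphenyl on that oxygen cannot be told apart here. Among these four compounds, only compound 2, which carries the amino group, stands apart from the others by more than the scatter.

The compounds shown leave open whether the amino group would have the same effect without the methoxy group, and whether a hydroxyl or dimethylamino group in its place would match it. Nothing measured here explains how the amino group produces this step.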